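From Ketone to Thioether: Expected Cytotoxicity of Compound 4

A few compounds are considered here, and "the series" means these few. Any claim that something is new, unique, unknown or untested is made for them only; others in the source may bear on it.

Of the compounds shown here, three built on one shared core have been tested in an ADME assay on cells (Homo sapiens) for cytotoxicity, read by resazurin assay, with a stated time of 5 days; on this read-out lower numbers stand for higher toxicity in this test and higher numbers for lower toxicity in this test. Compound 2 `COc1ccc(-c2nc(CC(=O)c3cccc(Cl)c3)nc3ccsc23)cn1` is the only one of them that gives an actual number, 30000 nM in this assay. Compound 1 `COc1ccc(-c2nc(C(C)S(=O)(=O)c3cccc(Cl)c3)nc3ccsc23)cn1` reaches only a limit of the assay, > 50000 nM, and not a number. Compound 3 `COc1ccc(-c2nc(C(F)S(=O)(=O)c3cccc(Cl)c3)nc3ccsc23)cn1` likewise stops at a limit, > 50000 nM. Within the data shown here, the single one-place step among the measured compounds, a step that the two limits leave unreadable from compound 1 to compound 3, cannot be sized because both of its ends sit at the limit of > 50000 nM in this assay, at which 2 of the 3 values shown sit.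

Compound 4 `COc1ccc(-c2nc(CSc3cc(Cl)ccc3Cl)nc3ccsc23)cn1` has not yet been measured. It differs from compound 2 in one place: (2,5-dichlorophenyl)sulfanyl in place of (3-chlorophenyl)carbonyl on a saturated chain carbon bound to an aromatic carbon. Among the measured compounds shown here, no measured step touches this part of the molecule, so the expectation rests on compound 2 alone and on the fact that two of the three known values sit at the limit. Compound 4 is therefore expected to land at about 40000 nM, with a likely range from 15000 nM to 60000 nM, and a fair chance that only a limit is reported. The step this estimate means, a 1.3-fold higher number from compound 2 to compound 4 (0.12 log units; within the scatter), is expected to be small, with no direction that can be called beyond the scatter.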

Compound 4, half-maximal cytotoxic concentration: > 50000 nM
Compound 4: no number, only a limit; the forecaster's own chance of this, stated with the estimate: 45%; at least 1.2-fold (0.09 log units) between middle value and limit.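

Among these compounds, this is the first step that can be read at this place, on a saturated chain carbon bound to an aromatic carbon: putting (2,5-dichlorophenyl)sulfanyl in place of (3-chlorophenyl)carbonyl gives an at least 1.6-fold higher number from compound 2 to compound 4 (0.22 log units; that floor lies within the scatter) in this assay. Its floor lies within the scatter, so the step alone does not establish a real rise, yet the change shows no sign of higher toxicity in this test, since a lower number would mean that. The one measured number among these compounds therefore remains that of compound 2, and the scale offers little room to tell the others apart: the limit of > 50000 nM in this assay, at which 3 of the 4 values shown sit.

From the compounds shown here alone, the true size of the step stays open, and so does its source, since the sulfur replaces the carbonyl and the ring gains a second chlorine in the same change; a (3-chlorophenyl)sulfanyl group at this place would separate the two. Going by these compounds, it is also open whether a quite different group here, such as an amine or a carboxylic acid, would give a number rather than a limit.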